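The source may hold more compounds than are shown below. What is called first, only, known or untested is meant among the compounds shown, and "the series" means these compounds.

Compound 1 `O=C1Nc2ccccc2/C1=C/c1ccc(-c2cn(-c3ccccc3Cl)nn2)cc1`: > 20000 nM
Compound 2 `O=C1Nc2ccccc2/C1=C/c1ccc(-c2cn(-c3ccc(Cl)cc3)nn2)cc1`: 16200 nM

Among the compounds with values here, in a functional assay on MKN-45 cells (Homo sapiens) for inhibition, read by CCK-8 assay, with a stated time of 24 h (a higher number here means a weaker inhibitor, a lower number a stronger inhibitor), compound 2 gives 16200 nM, the only actual number so far. The entry for compound 1, > 20000 nM, is a limit and not a number. Compound 2 therefore has no measured number to be ranked against.

The next compound, compound 3 `N#Cc1cccc(-n2cc(-c3ccc(/C=C4\C(=O)Nc5ccccc54)cc3)nn2)c1`, keeps the shared core and changes only the group on the aromatic nitrogen of the five-membered ring. It has 3-cyanophenyl in place of 4-chlorophenyl (3-cyanophenyl in place of 4-chlorophenyl on an aromatic nitrogen).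

Within the data shown here, one measured step bears on this, since it changes a group at the same place: an at least 1.2-fold lower number from compound 1 to compound 2 (0.09 log units; that floor lies within the scatter). Among the measured compounds shown here, that step is small, and it involves only chlorophenyl groups, so no measured compound shows what a nitrile does here. With this single step as the guide, no change beyond the usual scatter is expected in this assay. The expected change is a 1.2-fold lower number from compound 2 to compound 3 (0.06 log units; within the scatter). For compound 3 the estimated value is 14000 nM, with an expected range from 5000 nM to 30000 nM.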

Compound 3, half-maximal inhibitory concentration: > 20000 nM
Compound 3: only a limit was reported; the forecaster's own chance of this, stated with the estimate: 35%; at least 1.4-fold (0.15 log units) between middle value and limit.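

Within the data shown here, a nitrile reaches this position for the first time, on 3-cyanophenyl, and the change from 4-chlorophenyl gives an at least 1.2-fold higher number from compound 2 to compound 3 (0.09 log units; that floor lies within the scatter) in this assay. The entry for compound 3 is a limit and not a number, so this nitrile shows no readable gain over the 4-chlorophenyl group. The true size of that step stays hidden, and the step between compound 1 and compound 3 cannot be read at all, because each of these two compounds has only a limit: the limit of > 20000 nM in this assay, at which 2 of the 3 values shown sit.

The compounds shown carry only chlorophenyl and 3-cyanophenyl groups on this nitrogen, so they leave open what a phenyl ring bearing an amine or a carboxylic acid, or a longer chain in place of the ring, would do. With a single actual number in the series, they also leave open whether any group at this position can bring the value clearly lower than that of compound 2, 16200 nM.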